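The source may report more compounds than this note shows. Statements on the series, on what has been measured and on what is new or still open speak of the compounds shown alone.

Compound 1 `CCN(CC)C(=O)Cc1c(-c2ccc(OC3CCCC3)cc2)nn2c(C)cc(C)nc12` gives 1.5 nM in an assay on isolated protein (kidney, strain Wistar) for displacement of a labelled ligand from Translocator protein (Rattus norvegicus), read by scintillation counting, with a stated time of 90 min; a lower number here means a stronger inhibitor, a higher number a weaker inhibitor; compound 2 `CCN(CC)C(=O)Cc1c(-c2ccc(OCC3CC3)cc2)nn2c(C)cc(C)nc12` gives 3 nM; compound 3 `CCN(CC)C(=O)Cc1c(-c2ccc(OCc3ccccc3)cc2)nn2c(C)cc(C)nc12` gives 0.99 nM.

Compound 3 has the lowest of the three numbers, though the step of a 1.5-fold lower number from compound 1 to compound 3 (0.18 log units; within the scatter) stays within the scatter, while a 3.0-fold lower number from compound 2 to compound 3 (0.48 log units; beyond the scatter) lies beyond it. Compound 4 `CCN(CC)C(=O)Cc1c(-c2ccc(OCc3cccc(F)c3)cc2)nn2c(C)cc(C)nc12` differs from compound 3 by fluoro in place of hydrogen on an aromatic carbon. The measured steps all concern the group on the oxygen itself, so none of them tests a substituent on the benzyl ring; they show only that the benzyl series sits at the low end. Among the measured compounds shown here, with no direct precedent, the step is expected to be a 1.0-fold higher number from compound 3 to compound 4 (0.00 log units; within the scatter). Compound 4 is estimated at 1 nM, with a range from 0.4 nM to 2.5 nM.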

Compound 4, inhibition constant: 0.47 nM
Estimate against measurement, compound 4: 2.1-fold (0.33 log units) above; measured number inside the range.
By their numbers in this assay, from the lowest: compound 4; then compounds 3, 1 and 2 (each within the scatter of the next, the first and the last beyond it).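

In this assay, a substituent on the benzyl ring moves the number, which the changes to the group on the oxygen could not show: fluoro in place of hydrogen gives a 2.1-fold lower number from compound 3 to compound 4 (0.32 log units; beyond the scatter). The 3-fluorobenzyl group also stands clear of both other groups on the oxygen, with a 3.2-fold lower number from compound 1 to compound 4 (0.50 log units; beyond the scatter) and a 6.4-fold lower number from compound 2 to compound 4 (0.81 log units; beyond the scatter). Nothing available here accounts for the effect of the fluoro group. The compounds shown leave open whether chloro or methoxy on the same carbon would act like fluoro. They also leave open how fluoro would behave on another carbon of that ring.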